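The compounds below may be only part of what the source reports. "The series", "measured", "known", "first", "only" and "open" are said of these compounds alone.

Measured compounds in a functional assay on MCF7 cells (Homo sapiens) for cytotoxicity, read by MTT assay, with a stated time of 72 h, tested at 100 uM; a lower number here means less inhibition of growth, a higher number more inhibition of growth at the concentration tested:
- compound 1 `Cc1cccc(/C(N)=N/NC(=S)N2CCSCC2)n1` gives 46.8%
- compound 2 `N/C(=N\NC(=S)N1CCSCC1)c1ccccn1` gives 72.4%
- compound 3 `N/C(=N\NC(=S)N1CCCCC1)c1ccccn1` gives 77.7%

Compound 3 has the highest of the three numbers, but its gap to compound 2 is within the scatter, so the two are not told apart. Compound 2 and compound 3 differ only at the thiocarbonyl carbon: piperidin-1-yl in place of thiomorpholin-4-yl on a thiocarbonyl carbon That change made a number 5.3 percentage points higher from compound 2 to compound 3 (within the scatter), within the scatter. Within the data shown here, compound 1 differs from compound 2 by methyl in place of hydrogen on an aromatic carbon That step made a number 25.6 percentage points lower from compound 2 to compound 1 (beyond the scatter), the one modest step beyond the scatter seen here.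

Compound 4 `Cc1ccnc(/C(N)=N/NC(=S)N2CCCCC2)c1` is not yet measured. It differs from compound 3 by methyl in place of hydrogen on an aromatic carbon This is the same kind of change as from compound 2 to compound 1, occurring twice in all, but not the same: in compound 1 the methyl sits next to the ring nitrogen, in compound 4 it sits opposite the ring nitrogen, both meta to a large group. Because compound 1 showed a number 25.6 percentage points lower from compound 2 to compound 1 (beyond the scatter), a lowering is expected from compound 3 to compound 4 as well, estimated at a number 17.7 percentage points lower from compound 3 to compound 4 (beyond the scatter), though the different place leaves this uncertain. Compound 4 is therefore expected at 60%, between 44% and 78%.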

Compound 4, percent growth inhibition at one concentration: 80.1%
Beside the measured number, compound 4's estimate is 20.1 percentage points below it; measured number outside the range, above it.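

In this assay, methyl in place of hydrogen on an aromatic carbon, opposite the ring nitrogen, gave a number 2.4 percentage points higher from compound 3 to compound 4 (within the scatter), which leaves compound 4 not told apart from compound 3. Set beside the earlier step, the same change did not carry the same result from one core to the other: the same change on two cores in this assay, a number 25.6 percentage points lower (beyond the scatter) from compound 2 to compound 1 and a number 2.4 percentage points higher (within the scatter) from compound 3 to compound 4, 28 percentage points apart, beyond the scatter of two such steps This does not show what separates the two steps, since they differ both in where the methyl sits on the ring and in the group on the thiocarbonyl carbon, thiomorpholin-4-yl in one and piperidin-1-yl in the other, and two steps make no rule for the series.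

The compounds shown leave open which of those two differences matters, as neither methyl position appears with both thiocarbonyl groups. They also leave open how an ethyl or a methoxy group would compare with methyl on the ring, and how a morpholin-4-yl group would compare on the thiocarbonyl carbon.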